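The source may hold more compounds than are shown below. What is called first, only, known or untested is meant among the compounds shown, and "the series" means these compounds.

Measured so far in a functional assay on HCT-116 cells (Homo sapiens) for antiproliferative activity, read by MTT assay, with a stated time of 48 h; a higher number here means a weaker inhibitor, a lower number a stronger inhibitor:
Compound 1 `CCCCCCCCC[C@H](CCO)n1cnc2c(Cl)ncnc21`: 450 nM
Compound 2 `CCCCCCCCC[C@H](CCn1cc(-c2ccccc2)nn1)n1cnc2c(Cl)ncnc21`: 8130 nM

Compound 2, at 8130 nM, has the higher of the two numbers and is the weaker inhibitor of the pair in this assay. Compound 3 `CCCCCCCCC[C@H](CCCl)n1cnc2c(Cl)ncnc21` differs from compound 2 at one place: chloro in place of 4-phenyl-1H-1,2,3-triazol-1-yl on a saturated chain carbon, three bonds along the chain from an aromatic nitrogen.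

Within the data shown here, only one measured step bears on this change. It is an 18-fold higher number from compound 1 to compound 2 (1.26 log units; beyond the scatter), a large step beyond the scatter, made when the same triazolyl group replaced hydroxy at this place. Compound 3 loses that group, so a sizeable step toward a lower number is expected, back in the direction of compound 1 at 450 nM. Among the measured compounds shown here, no measured compound carries chloro at this place, so a full return cannot be assumed. The estimated step is a 7.4-fold lower number from compound 2 to compound 3 (0.87 log units; beyond the scatter). For compound 3, the expected value is 1100 nM, with an estimated range of 300 nM to 4000 nM.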

Compound 3, half-maximal inhibitory concentration: 9580 nM
Beside the measured number, compound 3's estimate is 8.7-fold (0.94 log units) below it; the whole stated range lies below it.
By their numbers in this assay, from the lowest: compound 1; then compounds 2 and 3 (each within the scatter of the next).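

In this assay the exchange of the 4-phenyl-1H-1,2,3-triazol-1-yl group, with its 11 heavy atoms and two aromatic rings, for a single chloro atom gives a 1.2-fold higher number from compound 2 to compound 3 (0.07 log units; within the scatter) and so produces no difference that can be told apart from the usual scatter between repeated measurements. At the same saturated chain carbon, chloro in place of hydroxy gives a 21-fold higher number from compound 1 to compound 3 (1.33 log units; beyond the scatter) and stands alongside an 18-fold higher number from compound 1 to compound 2 (1.26 log units; beyond the scatter) as a second large step, so two entering groups of very different size both leave the number far from that of compound 1. Among these three compounds the large step thus follows the replacement of hydroxy and not the size of the group that enters, and nothing available explains why.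

The compounds shown leave open whether any group other than hydroxy at this place can keep a number close to that of compound 1; an amine, a methoxy group or a carboxylic acid could fall on either side. They also leave open whether the same pattern would hold with a shorter alkyl chain in place of the long one.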